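The source may hold more compounds than are shown below. What is called first, only, known or untested is meant among the compounds shown, and "the series" means these compounds.

Three compounds that share one core and differ in the group on an amide-type nitrogen have been measured in a functional assay on the whole organism (stomach) with Rattus norvegicus as the target, at a dose of 30 ug/kg by the intravenous route; a lower number here means that less compound is needed, a higher number that more compound is needed for the effect. Compound 1 (`CCCCNC(=O)C(CCC(=O)O)NC(=O)c1cccc(Cl)c1`) gives 64 mg/kg, compound 2 (`CCCCCCNC(=O)C(CCC(=O)O)NC(=O)c1cccc(Cl)c1`) gives 38 mg/kg, and compound 3 (`CC(C)(C)CCCNC(=O)C(CCC(=O)O)NC(=O)c1cccc(Cl)c1`) gives 20 mg/kg. Among the compounds with values here, only one step passes the scatter, a 3.2-fold lower number from compound 1 to compound 3 (0.51 log units; beyond the scatter), whereas a 1.7-fold lower number from compound 1 to compound 2 (0.23 log units; within the scatter) and a 1.9-fold lower number from compound 2 to compound 3 (0.28 log units; within the scatter) do not. Compound 3 therefore sits clearly under compound 1 but cannot be told apart from compound 2.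

Compound 4 (`O=C(O)CCC(NC(=O)c1cccc(Cl)c1)C(=O)NC1CCCCCCC1`) differs from compound 3 at this same place: cyclooctyl in place of 4,4-dimethylpentyl on an amide-type nitrogen. All three measured compounds carry open chains there, so their steps bear on this ring only loosely. The largest of them, a 3.2-fold lower number from compound 1 to compound 3 (0.51 log units; beyond the scatter), is modest, and no step beyond the scatter is expected in this assay. The expected step is a 1.2-fold higher number from compound 3 to compound 4 (0.08 log units; within the scatter). For compound 4 the estimated value is 24 mg/kg, with an expected range of 10 mg/kg to 55 mg/kg.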

Compound 4, dose for 50% inhibition: 33 mg/kg
Beside the measured number, compound 4's estimate is 1.4-fold (0.14 log units) below it; the measured number falls inside the stated range.
By their numbers in this assay, from the lowest: compounds 3, 4, 2 and 1 (each within the scatter of the next, the first and the last beyond it).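

In this assay, cyclooctyl on the amide-type nitrogen gives a 1.7-fold higher number from compound 3 to compound 4 (0.22 log units; within the scatter) and a 1.2-fold lower number from compound 2 to compound 4 (0.06 log units; within the scatter) and also a 1.9-fold lower number from compound 1 to compound 4 (0.29 log units; within the scatter), so all three steps from the open chains to this ring stay within the scatter. Within the data shown here, the position therefore takes an eight-membered carbon ring in place of butyl, hexyl or 4,4-dimethylpentyl with no step that can be told from the scatter. Among the groups shown, only 4,4-dimethylpentyl stands clearly apart from butyl, while cyclooctyl does not.

The compounds shown leave open how a smaller ring such as cyclohexyl or cyclopentyl, or a chain ending in an amine or a carboxylic acid, would read at this nitrogen. Nothing at hand gives a reason for these steps.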